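Swapping a Ring Oxygen for Nitrogen on a Fast-Cleared Compound

The compounds below may be only part of what the source reports. "The series", "measured", "known", "first", "only" and "open" are said of these compounds alone.

Measured so far:
- compound 1 `O=C1OCCN1CCOc1nn(-c2ccccc2F)c2ccc(F)cc12` — 683 mL/min/kg
- compound 2 `CC(C)(O)CC(=O)N1CC[C@H]2CN(c3cccc4c3cnn4-c3ccccc3F)C(=O)[C@H]21` — 58.3 mL/min/kg
- compound 3 `CC(C)(C)OC(=O)N1CCN(c2cccc3c2cnn3-c2ccccc2F)C1=O` — 98.3 mL/min/kg

In an ADME assay on liver for metabolic stability, with Liver microsome (Homo sapiens) as the target, using microsomes and NADPH, with a stated time of 30 min, tested at 0.5 uM (on this read-out higher numbers stand for fast clearance and lower numbers for slow clearance), compound 1 gives 683 mL/min/kg, the highest of the three numbers. Compound 3 gives 98.3 mL/min/kg and compound 2 gives 58.3 mL/min/kg, both well beyond the scatter from compound 1, so compound 1 is cleared fastest of the three.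

Compound 4 `O=C1NCCN1CCOc1nn(-c2ccccc2F)c2ccc(F)cc12` differs from compound 1 in one place: 2-oxoimidazolidin-1-yl in place of 2-oxo-1,3-oxazolidin-3-yl on a saturated chain carbon, two bonds along the chain from an oxygen on an aromatic ring. Within the data shown here, no pair of measured compounds shows this change, so its effect is unknown. Compound 4 is expected to move toward slower clearance in this assay by a 1.5-fold lower number from compound 1 to compound 4 (0.18 log units; within the scatter), a step that may not exceed the scatter. The estimate for compound 4 is 450 mL/min/kg, between 200 mL/min/kg and 1000 mL/min/kg.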

Compound 4, clearance: 183 mL/min/kg
Compound 4: middle estimate off by 2.5-fold (0.39 log units), on the high side; measured number below the stated range.
By their numbers in this assay, from the lowest: compounds 2, 3 and 4 (each within the scatter of the next, the first and the last beyond it); then compound 1.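

In this assay, 2-oxoimidazolidin-1-yl in place of 2-oxo-1,3-oxazolidin-3-yl gives a 3.7-fold lower number from compound 1 to compound 4 (0.57 log units; beyond the scatter) on an otherwise unchanged compound. Among these compounds, this is the first matched pair at this position, and it shows that swapping one ring oxygen for nitrogen, which adds a hydrogen-bond donor, is enough to lower the clearance number beyond the scatter. Nothing available here explains the step.

As far as these compounds go, it remains open whether a methyl group on that ring nitrogen would keep the lower number, and whether a piperidine ring at the end of the chain would do the same.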